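Trimming the benzyl substituents of a trimethoxyphenyl amide series

The source may hold more compounds than are shown below. What is called first, only, known or untested is meant among the compounds shown, and "the series" means these compounds.

Compound 1 `COc1ccc(CN(C(=O)CSc2nc3ccccc3s2)c2cc(OC)c(OC)c(OC)c2)cc1C` is one of three close relatives that share the same core and differ only in the benzyl group on the saturated chain carbon bound to the amide-type nitrogen. In a functional assay on MGC-803 cells (Homo sapiens) for antiproliferative activity, read by MTT assay, with a stated time of 48 h (a higher number here means a weaker inhibitor, a lower number a stronger inhibitor), compound 1 gives 6360 nM, the second highest of the three numbers. Compound 2 `COc1cc(N(Cc2ccc(C)cc2)C(=O)CSc2nc3ccccc3s2)cc(OC)c1OC` gives 54200 nM, and compound 3 `COc1ccc(CN(C(=O)CSc2nc3ccccc3s2)c2cc(OC)c(OC)c(OC)c2)cc1[N+](=O)[O-]` gives 682 nM. The two steps from compound 1 are an 8.5-fold higher number from compound 1 to compound 2 (0.93 log units; beyond the scatter) and a 9.3-fold lower number from compound 1 to compound 3 (0.97 log units; beyond the scatter); between the other pair the step is a 79-fold lower number from compound 2 to compound 3 (1.90 log units; beyond the scatter).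

Compound 4 `COc1cc(N(Cc2ccccc2)C(=O)CSc2nc3ccccc3s2)cc(OC)c1OC` carries the change (phenyl in place of 4-methoxy-3-methylphenyl on a saturated chain carbon bound to an amide-type nitrogen). Going by the values given here, the step that bears most directly on it is the one to compound 2, where dropping the methoxy and keeping only a methyl already gave an 8.5-fold higher number from compound 1 to compound 2 (0.93 log units; beyond the scatter). Removing both groups is therefore expected to move the number in the same direction, beyond the scatter, by about a 4.7-fold higher number from compound 1 to compound 4 (0.67 log units; beyond the scatter). Compound 4 is estimated to give 30000 nM, within 8000 nM to 110000 nM.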

Compound 4, half-maximal inhibitory concentration: 44300 nM
The estimate for compound 4 lay 1.5-fold (0.17 log units) below the measured number, within the range that was stated.
By their numbers in this assay, from the lowest: compound 3; then compound 1; then compounds 4 and 2 (each within the scatter of the next).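

Taking the ring down to plain phenyl gives a 7.0-fold higher number from compound 1 to compound 4 (0.84 log units; beyond the scatter) and so confirms the loss seen with compound 2 at this position, while hydrogen in place of methyl on the aromatic carbon gives a 1.2-fold lower number from compound 2 to compound 4 (0.09 log units; within the scatter) and leaves compounds 2 and 4 unseparated. The 4-methylphenyl and phenyl groups therefore sit together at the weak end of this short series, and measured against that plain benzyl baseline, the nitro-bearing group of compound 3 stands apart, with a 65-fold higher number from compound 3 to compound 4 (1.81 log units; beyond the scatter) as the step. Nothing measured here explains these steps.

On these data alone, whether a lone methoxy on the ring, as in 4-methoxyphenyl, would already recover part of the loss remains open. So does what an amine or a carboxylic acid would give in place of nitro on that aromatic carbon.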